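A fluorophenyl group on a compound at the assay limit

The compounds below may be only part of what the source reports. "The series", "measured", "known", "first", "only" and "open" are said of these compounds alone.

Values measured in an ADME assay on BaF3 cells (Mus musculus) for cytotoxicity, read by MTT assay, with a stated time of 48 h; a lower number here means a stronger inhibitor of growth, a higher number a weaker inhibitor of growth:
Compound 1 `CC(C)n1nc(-c2cc(C(C)(C)C)on2)c2c(N)ncnc21` gives > 10000 nM
Compound 2 `CC(C)c1cc(-c2nn(C(C)C)c3ncnc(N)c23)no1` gives > 10000 nM

Compound 2 stands at > 10000 nM, which is a limit of this assay and not a number. Compound 1 stands at > 10000 nM, which is also a limit. The measured series therefore comes down to one reading: the limit of > 10000 nM in this assay, at which 2 of the 2 values shown sit. Among the measured compounds shown here, the only measured step is a step that the two limits leave unreadable from compound 1 to compound 2, so it offers no size to carry forward.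

Compound 3 `CC(C)n1nc(-c2cc(-c3ccc(F)cc3)on2)c2c(N)ncnc21` has 4-fluorophenyl in place of isopropyl on an aromatic carbon, next to the ring oxygen of the five-membered aromatic ring: 4-fluorophenyl in place of isopropyl on an aromatic carbon. For the measured compounds named here, no measured compound carries an aromatic ring at this place, and no readable step bears on the change. Going by the values given here, no step of definite size or direction can be expected in this assay, and compound 3 is expected to stay close to the limit, quite possibly reported only as a limit.

The estimated change is a number no higher from compound 2 to compound 3 (the limit leaves the size open). Compound 3 is expected at 10000 nM, with an estimated range from 4000 nM to 25000 nM.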

Compound 3, concentration for 50% growth inhibition: > 10000 nM
Compound 3: no number, only a limit; the forecaster's own chance of this, stated with the estimate: 75%; the middle value sits exactly at the limit.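

No new step can be read from compound 1 or compound 2 to compound 3, because the series still comes down to one reading: the limit of > 10000 nM in this assay, at which 3 of the 3 values shown sit.

The compounds shown leave open whether any group at this place on the shared core would give a number rather than a limit in this assay.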